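Thiourea series: removing the chloro substituent

The source may report more compounds than this note shows. Statements on the series, on what has been measured and on what is new or still open speak of the compounds shown alone.

Measured so far:
compound 1, `C/N=C(/NC#N)NCCCn1nc(-c2ccccc2)ccc1=O` — 40.5%
compound 2, `O=c1ccc(-c2ccccc2)nn1CCCCNC(=S)Nc1ccc(Cl)cc1` — 43.2%
compound 3, `O=c1ccc(-c2ccccc2)nn1CCCC/N=C(\S)Nc1cccc(F)c1` — 30.4%

In a functional assay on the whole organism with Rattus norvegicus as the target, at a dose of 100 mg/kg (a higher number here means more inhibition at the dose given (going by the name of the read-out), a lower number less inhibition), compound 2 gives 43.2%, the top number of the three. The gap to compound 1 lies within the usual scatter, so no order between these two can be read from the data; compound 3 sits below compound 2 by a margin beyond the scatter. Compound 3 also differs from compound 2 in more than one place, so nothing isolates a single change among the measured compounds.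

Compound 4, `O=c1ccc(-c2ccccc2)nn1CCCCNC(=S)Nc1ccccc1`, is the next case to settle. It differs from compound 2 as follows: hydrogen in place of chloro on an aromatic carbon. For the measured compounds named here, no measured pair shows this change on its own, so the expected step rests only on the general standing of compound 2. The expectation is a small step downward in this assay, or none beyond the scatter, since the three measured numbers cluster within a modest band and the change is a single heavy atom.

Compound 4 is estimated at 36%, with a range from 22% to 50%; this corresponds to an expected step of a number 7.2 percentage points lower from compound 2 to compound 4 (within the scatter).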

Compound 4, a percentage reported as inhibition, in the whole organism at one dose (the size of the read-out at that dose, not a potency): 38.4%
For compound 4 the middle estimate is 2.4 percentage points below the measured one; low and high end bracket the measured number.
By their numbers in this assay, from the lowest: compounds 3, 4, 1 and 2 (each within the scatter of the next, the first and the last beyond it).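

For the compounds shown here, replacing chloro with hydrogen gives the first single-place comparison: in this assay, the change from 4-chlorophenyl to phenyl is a number 4.8 percentage points lower from compound 2 to compound 4 (within the scatter). At this position on the aromatic ring, para to a large group, the chloro is therefore not shown to matter for the inhibition seen at this dose, and the (4-chlorophenyl)amino and anilino forms cannot be ranked against each other from this one pair. No supporting data bear on this result, so it stands as an observation without an explanation.

From the compounds shown here alone, a single substitution pair cannot show whether this position is generally insensitive, and whether a methoxy group, a nitrile or a dimethylamino group in the same place would move the number beyond the scatter remains open. Also open, going by these compounds, is whether a longer chain between the shared core and the thiourea would change the read-out of compound 4 in this assay, with the phenyl group left as it is.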